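A Methyl Group on the Chain of Compound 3

The compounds below may be only part of what the source reports. "The series", "measured", "known", "first", "only" and "open" are said of these compounds alone.

In an ADME assay on LLC-PK11 cells (Sus scrofa) for cytotoxicity (a higher number here means a weaker inhibitor, a lower number a stronger inhibitor), compound 1 (`Clc1ccc2cc(NCCCCNc3nc(NC4CCCCC4)nc(N4CCCCC4)n3)cnc2c1`) gives 8400 nM and compound 2 (`Clc1ccc2cc(NCCNc3nc(Nc4ccccc4)nc(Nc4ccccc4)n3)cnc2c1`) gives 11200 nM while compound 3 (`Cc1ccccc1Nc1nc(NCCNc2cnc3cc(Cl)ccc3c2)nc(Nc2ccccc2C)n1`) gives 8600 nM on the same read-out. Compound 3 thus lies within the scatter of both other compounds, and the three numbers cannot be ranked. No two of these compounds differ in one place only, so the data contain no direct measure of a single structural change.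

Compound 4 (`Cc1ccccc1Nc1nc(Nc2ccccc2C)nc(NC(C)CNc2cnc3cc(Cl)ccc3c2)n1`) departs from compound 3 in one place (methyl in place of hydrogen on a saturated chain carbon bound to a nitrogen on an aromatic ring and a saturated chain carbon), with methyl in place of hydrogen on a saturated chain carbon bound to a nitrogen on an aromatic ring and a saturated chain carbon. No step beyond the scatter is expected in this assay for this change. Among the measured compounds shown here, the basis for that expectation is limited: compound 3 differs in more than one place from compound 1, which gives 8400 nM and still lies within the scatter of compound 3, but no measured pair isolates a methyl on the chain. The estimated step is a 1.1-fold lower number from compound 3 to compound 4 (0.03 log units; within the scatter) and is expected to stay inside the scatter. For compound 4 the estimated value is 8000 nM with 3500 nM to 16000 nM as its expected range.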

Compound 4, half-maximal inhibitory concentration: 9000 nM
For compound 4 the middle estimate is 1.1-fold (0.05 log units) below the measured one, and the stated range covers the measured number.
By their numbers in this assay, from the lowest: compounds 1, 3, 4 and 2 (each within the scatter of the next).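

In this assay, methyl in place of hydrogen on a saturated chain carbon bound to a nitrogen on an aromatic ring and a saturated chain carbon gives a 1.0-fold higher number from compound 3 to compound 4 (0.02 log units; within the scatter), the first direct measure of a single structural change in this set. The result shows that this position takes on the added methyl without a step beyond the scatter in this read-out, which compound 1, compound 2 and compound 3 could not show, as no two of them differ in one place only. Nothing measured here points to a cause for this result.

The compounds shown leave open whether an ethyl group, a hydroxymethyl group, an amine or a carboxylic acid in the same place would also stay within the scatter, since methyl is the only group shown there. They also leave open whether the same methyl would give a similar step on the chain of compound 1 or compound 2, which carry other groups on the shared core.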